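A Larger Group on the Amine Nitrogen in a Ring

A few compounds are considered here, and "the series" means these few. Any claim that something is new, unique, unknown or untested is made for them only; others in the source may bear on it.

Compound 1 (`NC(=O)c1c(NC(=O)c2ccccc2Cl)sc2c1CCN(Cc1ccccc1F)C2`) was tested in a functional assay on HeLa cells (Homo sapiens) for antiproliferative activity, with a stated time of 24 h; on this read-out higher numbers stand for weaker inhibition and lower numbers for stronger inhibition. In this assay compound 1 gives only a limit, > 50000 nM, and not a number. Compound 2 (`NC(=O)c1c(NC(=O)c2ccc(C(F)(F)F)cc2)sc2c1CCN(Cc1ccccc1F)C2`) differs from it only in the group on the carbonyl carbon, and in this assay compound 2 likewise gives a limit, > 50000 nM. Compound 3 (`NC(=O)c1c(NC(=O)c2ccc(C(F)(F)F)cc2)sc2c1CCN(Cc1ccc(Cl)cc1Cl)C2`) carries 2,4-dichlorophenyl on the saturated chain carbon bound to the amine nitrogen in a ring, and in this assay compound 3 also gives a limit, > 50000 nM. The two steps between measured compounds, a step that the two limits leave unreadable from compound 1 to compound 2 and a step that the two limits leave unreadable from compound 2 to compound 3, cannot be read, since (the limit of > 50000 nM in this assay, at which 3 of the 3 values shown sit). Compound 1 thus stands at the limit together with the other two; nothing in the numbers separates the three.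

Compound 4 (`COc1ccccc1NC(=S)N1CCc2c(sc(NC(=O)c3ccccc3Cl)c2C(N)=O)C1`) is not yet measured. It differs from compound 1 as a group of 11 heavy atoms (8 carbon, 1 nitrogen, 1 oxygen, 1 sulfur; one six-membered aromatic ring of carbon only) in place of a group of 8 heavy atoms (7 carbon, 1 fluorine; one six-membered aromatic ring of carbon only), on an amine nitrogen in a ring. Of the measured steps, a step that the two limits leave unreadable from compound 2 to compound 3 concerns a group on the same side of the shared core, but its size is not readable, so no direction can be drawn from it. The step is therefore expected to be a step that the limit leaves unreadable from compound 1 to compound 4. Compound 4 is estimated to give about 80000 nM, within a range from 25000 nM to 250000 nM.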

Compound 4, half-maximal inhibitory concentration: > 50000 nM
Compound 4: only a limit was reported; the forecaster's own chance of this, stated with the estimate: 70%; the middle value is on the limit's open side.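

In this assay, among these compounds, compound 4 also gives only a limit, > 50000 nM, so the step from compound 1 to compound 4 cannot be read and no new step follows: the limit of > 50000 nM in this assay, at which 4 of the 4 values shown sit. The compounds shown leave open whether a change on the carbonyl carbon or on the amine nitrogen in a ring alters antiproliferative activity on the shared core at all.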